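Changing the Carbonyl-Side Ring of Compound 1

This account rests on a few compounds, and the source may have more. Where it says the series, first, only, none or still open, it means among the compounds named here.

Among the compounds with values here, compound 1 `O=C(CSc1cccc(O)c1)Nc1ccc2nc(NC(=O)c3ccc(F)cc3)sc2c1` gives 6170 nM in a functional assay on HCT-116 cells (Homo sapiens) for antiproliferative activity, read by MTT assay, with a stated time of 72 h (a lower number here means a stronger inhibitor, a higher number a weaker inhibitor), and holds the higher of the two numbers measured so far. Compound 2 `O=C(CSc1ccc(Cl)cc1)Nc1ccc2nc(NC(=O)c3ccc(F)cc3)sc2c1` gives 1360 nM in this assay with 4-chlorophenyl in place of 3-hydroxyphenyl on a sulfur.

Compound 3 `O=C(CSc1cccc(O)c1)Nc1ccc2nc(NC(=O)c3cc(Cl)cc(Cl)c3)sc2c1` keeps the sulfur side of compound 1 and differs elsewhere. The change is 3,5-dichlorophenyl in place of 4-fluorophenyl on a carbonyl carbon and it puts 3,5-dichlorophenyl in place of 4-fluorophenyl on a carbonyl carbon. Within the data shown here, no measured compound varies at that carbonyl carbon, so the evidence is indirect. Among the measured compounds shown here, the only measured step is a 4.5-fold lower number from compound 1 to compound 2 (0.66 log units; beyond the scatter) and it also brought chlorine onto a phenyl ring, but at a different place. On that thin basis, a smaller step toward a lower number is expected in this assay and one within the scatter remains quite possible. The expected change is a 2.1-fold lower number from compound 1 to compound 3 (0.31 log units; beyond the scatter) and it is only an estimate. In this assay the expected value for compound 3 is 3000 nM with a range from 1000 nM to 9000 nM as estimated here.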

Compound 3, half-maximal inhibitory concentration: 5440 nM
Estimate against measurement, compound 3: 1.8-fold (0.26 log units) below; the range from low to high includes it.
By their numbers in this assay, from the lowest: compound 2; then compounds 3 and 1 (each within the scatter of the next).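

Placing 3,5-dichlorophenyl in place of 4-fluorophenyl on the carbonyl carbon gives a 1.1-fold lower number from compound 1 to compound 3 (0.05 log units; within the scatter) in this assay, so this first measured change at that position leaves the two compounds indistinguishable in this read-out. The position therefore accepts a ring with two chlorine atoms in place of a ring with one fluorine atom, without a difference that can be separated from ordinary assay variation. Among the changes shown, only the one on the sulfur side, a 4.5-fold lower number from compound 1 to compound 2 (0.66 log units; beyond the scatter), goes beyond the scatter, although a single change at each place cannot show how either position behaves in general, and no accompanying measurement bears on the reason for this result.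

Going by these compounds, it remains open whether a different group on the carbonyl carbon, such as an amine, a carboxylic acid or a longer alkyl chain, would give a step beyond the scatter. Also open, on these data alone, is whether 3,5-dichlorophenyl on the carbonyl carbon would give the same picture with 4-chlorophenyl on the sulfur, the sulfur-side group of compound 2.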